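The compounds below may be only part of what the source reports. "The series", "measured", "known", "first", "only" and "open" are said of these compounds alone.

Compound 2 `C[C@@H](Oc1cc2oc(=O)n(CCC(=O)O)c2cc1Cl)c1ccc(Cl)cn1` gives the lowest of the two numbers recorded in an assay for inhibition of kynurenine 3-monooxygenase (Homo sapiens), read by mass spectrometry, with a stated time of 1 h (on this read-out higher numbers stand for weaker inhibition and lower numbers for stronger inhibition), a value of 3.16 nM. Its nearest neighbour is compound 1 `CCc1cc2oc(=O)n(CCC(=O)O)c2cc1Cl`, which in this assay gives 10 nM, a gap that lies beyond the scatter of repeated measurements. Compound 3 `C[C@@H](Oc1cc2oc(=O)n(CCC(=O)O)c2cc1Cl)c1ncco1` has not yet been measured. The change from compound 2 to compound 3 is 1,3-oxazol-2-yl in place of 5-chloropyridin-2-yl on a saturated chain carbon bound to an oxygen on an aromatic ring and a saturated chain carbon. Within the data shown here, no pair of measured compounds shows this kind of exchange, so there is no measured step to lean on. A modest loss of inhibition beyond the scatter is expected for compound 3, since the group that enters is smaller than the one that leaves, and the expected step is a 2.5-fold higher number from compound 2 to compound 3 (0.40 log units; beyond the scatter). On that basis compound 3 is expected to give 8 nM in this assay, with a range from 2.5 nM to 25 nM.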

Compound 3, half-maximal inhibitory concentration in the kynurenine 3-monooxygenase assay: 3.16 nM
Beside the measured number, compound 3's estimate is 2.5-fold (0.40 log units) above it; measured number inside the range.
By their numbers in the kynurenine 3-monooxygenase assay, from the lowest: compounds 2 and 3 (each within the scatter of the next); then compound 1.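

In the kynurenine 3-monooxygenase assay compound 2 gives 3.16 nM and compound 3 gives 3.16 nM. The exchange on this saturated chain carbon gives no change at the digits printed from compound 2 to compound 3 (within the scatter), so here the smaller 1,3-oxazol-2-yl serves as well as 5-chloropyridin-2-yl, and the other step, a 3.2-fold lower number from compound 1 to compound 3 (0.50 log units; beyond the scatter), shows that compound 3 also keeps the gap to compound 1. The same exchange is far from silent in a physicochemical assay for permeability, using PAMPA (a lower number here means that the compound crosses the layer more slowly, a higher number that the compound crosses the layer faster), where it gives an at least 20-fold lower number from compound 2 to compound 3 (1.30 log units; beyond the scatter). In the physicochemical assay compound 2 gives 60 nm/s. In the physicochemical assay compound 3 gives < 3 nm/s, which is a limit of the assay and not a number.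

The compounds shown leave open whether a 1,3-thiazol-2-yl or an unsubstituted pyridin-2-yl at this carbon would hold the number in the kynurenine 3-monooxygenase assay. They also leave open where such groups would fall in the physicochemical assay.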